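This account rests on a few compounds, and the source may have more. Where it says the series, first, only, none or still open, it means among the compounds named here.

Working notes on the series, read in a functional assay on the whole organism (strain Kunming) with Mus musculus as the target, in the formalin test, with a stated time of 0.5 h; a lower number here means that less compound is needed, a higher number that more compound is needed for the effect. Three esters sharing one core have been tested so far. Compound 1 (`COc1cc(OC)c(OC)cc1/C=C/COC(=O)/C=C/c1c(OC)ccc(OC)c1OC`) is reported only as a limit, <= 80 mg/kg, and is not a number that can be placed exactly. Compound 2 (`COc1cc(OC)c(OC)cc1/C=C/COC(=O)/C=C/c1ccc(Br)cc1`) gives a dose for half-maximal effect of 105 mg/kg. Compound 3 (`COc1cc(OC)c(OC)cc1/C=C/COC(=O)/C=C/c1cc(OC)c(OC)c(OC)c1`) gives 85.5 mg/kg, and these two values lie within the usual scatter of each other, so compound 2 cannot be separated from its nearest neighbour.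

The next compound is compound 4 (`COc1cc(OC)c(OC)cc1/C=C/COC(=O)/C=C/c1cccc(Br)c1`), an isomer of compound 2 with the same atoms joined differently. It carries 3-bromophenyl in place of 4-bromophenyl on a double-bonded chain carbon bound to a double-bonded chain carbon. Among the compounds with values here, no pair of tested compounds differs in only one place, so the series offers no direct measure of such a step in this assay. Within the data shown here, the only guide is that compound 2 also differs at this end of the molecule from compound 3, and compound 3 gives 85.5 mg/kg, within the scatter of compound 2. No change beyond the scatter is therefore expected, and no direction is favoured. The expected step of a 1.1-fold lower number from compound 2 to compound 4 (0.02 log units; within the scatter) is correspondingly small. For compound 4 the estimate is 100 mg/kg, with an expected range of 60 mg/kg to 170 mg/kg.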

Compound 4, dose for half-maximal effect: 113 mg/kg
Compound 4: the middle estimate sits 1.1-fold (0.05 log units) below what was measured, and the stated range covers the measured number.
By their numbers in this assay, from the lowest: compounds 3, 2 and 4 (each within the scatter of the next). At a limit, below all of these: compound 1.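

In this assay, within the data shown here, 3-bromophenyl in place of 4-bromophenyl on a double-bonded chain carbon bound to a double-bonded chain carbon gives a 1.1-fold higher number from compound 2 to compound 4 (0.03 log units; within the scatter), and this is the first step between two compounds that differ in one place. The two groups have the same atoms and the same counts, so this pair isolates where the bromine sits on the ring, and that change cannot be separated from the usual scatter of repeated measurements. This finding covers only these two bromophenyl groups at this position, and the pair gives no sign of how far the read-out can move when the group itself is replaced.

On these data alone, how an unsubstituted phenyl, or a phenyl carrying an amine or a carboxylic acid, would read at this position remains open, as does any change to the ester link or to the other end of the molecule. Compound 1 remains a limit and not a number, so its exact place relative to the other compounds also stays open: the limit of <= 80 mg/kg in this assay, at which 1 of the 4 values shown sits.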